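Allyl in place of 4-bromophenyl on the shared core

A few compounds are considered here, and "the series" means these few. Any claim that something is new, unique, unknown or untested is made for them only; others in the source may bear on it.

In an ADME assay on RAW264.7 cells (Mus musculus) for cytotoxicity, read by MTT assay, with a stated time of 48 h (a higher number here means that more compound is tolerated, a lower number that less compound is tolerated), compound 2 (`S=C(N/N=C\c1ccnc2ccccc12)Nc1ccc(Br)cc1`) gives 53500 nM and compound 1 (`S=C(N/N=C\c1ccnc2ccccc12)Nc1cccnc1`) gives 91600 nM on the same core. These two numbers lie within the scatter of each other, so compound 2 holds no distinct rank.

Compound 3 (`C=CCNC(=S)N/N=C\c1ccnc2ccccc12`) has allyl in place of 4-bromophenyl on an amide-type nitrogen, and the counted difference from compound 2 is allyl in place of 4-bromophenyl on an amide-type nitrogen on that nitrogen, whose other neighbour is the thiocarbonyl carbon.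

Among the compounds with values here, only one measured step bears on this change. It is a 1.7-fold lower number from compound 1 to compound 2 (0.23 log units; within the scatter) for 4-bromophenyl in place of pyridin-3-yl at the same place. Within the data shown here, that step exchanged one ring for another, whereas allyl brings no ring, so it is only a weak guide and the data hold no measured compound without a ring on that nitrogen.

No step beyond the scatter is therefore expected in this assay, and the estimated step is a 1.3-fold higher number from compound 2 to compound 3 (0.12 log units; within the scatter) in size. Compound 3 is estimated at 70000 nM in this assay with an expected range from 28000 nM to 170000 nM around that middle.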

Compound 3, half-maximal cytotoxic concentration: 105000 nM
For compound 3 the middle estimate is 1.5-fold (0.18 log units) below the measured one; measured number inside the range.
By their numbers in this assay, from the lowest: compounds 2, 1 and 3 (each within the scatter of the next).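

In this assay, within the data shown here, the earlier compounds both carried a six-membered aromatic ring on the amide-type nitrogen whose other neighbour is the thiocarbonyl carbon, and compound 3 is the first to carry a group with no ring there. Allyl gives a 2.0-fold higher number from compound 2 to compound 3 (0.29 log units; within the scatter) and a 1.1-fold higher number from compound 1 to compound 3 (0.06 log units; within the scatter) so the loss of the ring produces no step beyond the scatter against either ring-bearing compound, and the three compounds hold no distinct rank. The evidence available offers no account of these numbers.

Since every step among the three lies within the scatter, the compounds shown do not tell whether any group at this nitrogen can move the number in this assay by a clear margin. Also open, from the compounds shown here alone, is how a saturated propyl chain would compare with allyl, and whether a longer chain, or a chain ending in an amine or a carboxylic acid, would stay with these three or separate from them.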